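Dienone-triazole-coumarin conjugates: growth inhibition notes

The source may hold more compounds than are shown below. What is called first, only, known or untested is meant among the compounds shown, and "the series" means these compounds.

Measured compounds:
compound 1 `COc1cc(/C=C/C(=O)/C=C/c2ccccc2)ccc1OCc1cn(CCCOc2cc(=O)oc3ccccc23)nn1` — 48%
compound 2 `COc1cc(/C=C/C(=O)/C=C/c2cc(OC)c(OC)c(OC)c2)ccc1OCc1cn(CCCCCOc2cc(=O)oc3ccccc23)nn1` — 55%
compound 3 `COc1cc(/C=C/C(=O)/C=C/c2ccco2)ccc1OCc1cn(CCCCOc2cc(=O)oc3ccccc23)nn1` — 49%

In a functional assay on THP-1 cells (Homo sapiens) for inhibition, read by sulforhodamine B assay, with a stated time of 48 h, tested at 50 uM (a lower number here means less inhibition of growth, a higher number more inhibition of growth at the concentration tested), compound 1 gives 48%, the lowest of the three numbers. Compound 3 stands nearest to it, at 49%, and compound 2 furthest, at 55%; both gaps lie within the scatter of this assay, so the three measured compounds cannot be told apart by their numbers. Going by the values given here, no step between two measured compounds that differ in a single place is available, so the effect of a change at the aryl end of the dienone is not yet documented by a direct pair.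

Compound 4 `COc1ccc(/C=C/C(=O)/C=C/c2ccc(OCc3cn(CCCOc4cc(=O)oc5ccccc45)nn3)c(OC)c2)cc1OC` is the next compound to be measured. Relative to compound 1 the change is:
3,4-dimethoxyphenyl in place of phenyl on a double-bonded chain carbon bound to a double-bonded chain carbon

Compound 2, which also carries methoxy groups on this aryl ring, gives 55%, but it differs from compound 1 in the chain as well, so its number is only a loose pointer. The step from compound 1 to compound 4 in this assay is expected to be small and within the scatter, if anything slightly upward, a number 4 percentage points higher from compound 1 to compound 4 (within the scatter). Compound 4 is therefore estimated at 52%, in the range 40% to 64%.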

Compound 4, percent growth inhibition at one concentration: 73%
Compound 4: middle estimate off by 21 percentage points, on the low side; measured number above the stated range.
By their numbers in this assay, from the lowest: compounds 1, 3 and 2 (each within the scatter of the next); then compound 4.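

Within this assay the exchange of phenyl for 3,4-dimethoxyphenyl on a double-bonded chain carbon bound to a double-bonded chain carbon gives a number 25 percentage points higher from compound 1 to compound 4 (beyond the scatter) and is the first single-place step of the series. The earlier numbers lay within the scatter of one another and came from compounds that differ in more than one place, so they could not show that this position responds; with the chain of compound 1 kept, the aryl exchange alone now separates compound 4 from compound 1. No measurement at hand bears on the cause of this step.

Open, going by these compounds, is whether the step needs both methoxy groups or whether a single one would carry it, and whether other groups at this place, such as 4-hydroxy-3-methoxyphenyl or 4-dimethylaminophenyl, would give a comparable number. Also open, on these data alone, is whether the same exchange gives a step of similar size on the longer chains of compound 2 and compound 3, or whether it holds only on the chain of compound 1.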